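Arylpiperazine pyridazinones: indolyl for imidazolyl on the longer chain

A few compounds are considered here, and "the series" means these few. Any claim that something is new, unique, unknown or untested is made for them only; others in the source may bear on it.

Measured so far:
compound 1, `COc1ccccc1N1CCN(CCn2nc(-n3ccnc3)ccc2=O)CC1`, 237 nM
compound 2, `COc1ccccc1N1CCN(CCCCn2nc(-n3ccnc3)ccc2=O)CC1`, 47.5 nM
compound 3, `COc1ccccc1N1CCN(CCn2nc(-n3ccc4ccccc43)ccc2=O)CC1`, 22.7 nM

Three compounds of the series have been run in an assay on cell membranes from brain for binding affinity to Adrenergic receptor alpha-1 (Rattus norvegicus), read by radioligand binding; a higher number here means a weaker inhibitor, a lower number a stronger inhibitor. Compound 1 gives 237 nM, compound 2 gives 47.5 nM and compound 3 gives 22.7 nM. Compound 1 and compound 3 differ in one place: 1H-indol-1-yl in place of 1H-imidazol-1-yl on an aromatic carbon. This change made a large step, a 10-fold lower number from compound 1 to compound 3 (1.02 log units; beyond the scatter). Compound 2 sits between the two, with its number closest to that of compound 3. How the core of compound 2 differs from the core of compound 1 is not broken down here.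

Compound 4, `COc1ccccc1N1CCN(CCCCn2nc(-n3ccc4ccccc43)ccc2=O)CC1`, has not been measured in this assay. It stands to compound 2 as compound 3 stands to compound 1, and the change is the same one: 1H-indol-1-yl in place of 1H-imidazol-1-yl on an aromatic carbon. Among the compounds with values here, the place descriptions of the two changes agree word for word, so the same kind of step is expected, although only one earlier instance of it is known and it was made on the other core.

The expected step is a 7.9-fold lower number from compound 2 to compound 4 (0.90 log units; beyond the scatter), set slightly smaller than the earlier one because a 10-fold lower number from compound 1 to compound 3 (1.02 log units; beyond the scatter) was measured from a weaker starting point than compound 2 at 47.5 nM. Compound 4 is expected at 6 nM, with a likely range from 2 nM to 20 nM.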

Compound 4, inhibition constant: 0.9 nM
Compound 4: the middle estimate sits 6.7-fold (0.82 log units) above what was measured; the whole stated range lies above it.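

In this assay, 1H-indol-1-yl in place of 1H-imidazol-1-yl on an aromatic carbon again gives a lower number on the second core, with a 53-fold lower number from compound 2 to compound 4 (1.72 log units; beyond the scatter). The direction of the change carries from one core to the other, but its size does not: the same change on two cores in this assay, a 10-fold lower number (1.02 log units; beyond the scatter) from compound 1 to compound 3 and a 53-fold lower number (1.72 log units; beyond the scatter) from compound 2 to compound 4, 5.1-fold (0.70 log units) apart, beyond the scatter of two such steps

This shows that, in these two matched pairs, the gain from the change depends on the core that carries it, so the step measured on one core does not set its size on the other. Within the data shown here, it does not show what in the two cores produces the difference, and with only one pair per core it gives no rule for the size of the step on any further core.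

The compounds shown leave open whether the step follows from the added six-membered aromatic ring of carbon only or from the change in the five-membered ring, a question that a 1H-pyrrol-1-yl or a 1H-benzimidazol-1-yl group at the same aromatic carbon could address. Also open, going by these compounds, are how the change behaves on a core with a longer chain than that of compound 4, and how these pairs read at any other receptor.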